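Carboxylic acid on the benzyl group of compound 1

The compounds below may be only part of what the source reports. "The series", "measured", "known", "first", "only" and "open" are said of these compounds alone.

Compound 1 `Clc1cc(Cl)cc(CO[C@H]2CCCN(Cc3ccccc3)[C@H]2c2ccccc2)c1` carries a benzyl group on the ring nitrogen and a dichlorobenzyl ether on the saturated ring. In an assay on isolated protein for activation of cGMP-dependent protein kinase 1 (Homo sapiens), read by ADP-Glo, with stated times of 120 min and 40 min (on this read-out higher numbers stand for an effect only at larger amounts of compound and lower numbers for an effect already at smaller amounts), compound 1 gives > 200000 nM, which is a limit of the assay rather than a number. It therefore stands at the limit of > 200000 nM in this assay, at which 1 of the 3 values shown sits. Two related compounds do give numbers: compound 2 `OC[C@@H](O[C@H]1CCCN(Cc2ncc[nH]2)[C@H]1c1ccccc1)c1cc(Cl)cc(Cl)c1` reaches 7000 nM in this assay, and compound 3 `COC(=O)Nn1c(C[C@H]2CCC[C@H](OCc3cc(C(F)(F)F)cc(C(F)(F)F)c3)[C@@H]2c2ccccc2)n[nH]c1=O` reaches 4500 nM. Going by the values given here, both carry polar groups that compound 1 lacks, but no single-point step connects them to compound 1, so their values show only where measurable activity has been found.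

Compound 4 `COc1cc(C(=O)O)ccc1CN1CCC[C@H](OCc2cc(Cl)cc(Cl)c2)[C@@H]1c1ccccc1` differs from compound 1 in one place: 4-carboxy-2-methoxyphenyl in place of phenyl on a saturated chain carbon bound to an amine nitrogen in a ring. Among the compounds with values here, no measured step of this kind exists, so the expectation rests on the fact that the only numbers in this assay come from compounds 2 and 3, which carry polar groups, while compound 1 with its plain benzyl group stays at the limit. Compound 4 is therefore expected to move into measurable territory, the estimated step being an at least 6.6-fold lower number from compound 1 to compound 4 (0.82 log units; beyond the scatter). Compound 4 is estimated at 30000 nM, with a range from 4000 nM to 200000 nM, and a real chance that this assay again reports only a limit.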

Compound 4, half-maximal effective concentration: 62000 nM
The estimate for compound 4 lay 2.1-fold (0.32 log units) below the measured number, within the range that was stated.
By their numbers in this assay, from the lowest: compounds 3 and 2 (each within the scatter of the next); then compound 4. At a limit, above all of these: compound 1.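

In this assay, going by these compounds alone, 4-carboxy-2-methoxyphenyl in place of phenyl on a saturated chain carbon bound to an amine nitrogen in a ring gives an at least 3.2-fold lower number from compound 1 to compound 4 (0.50 log units; beyond the scatter), the only measured step at this position. The dichlorobenzyl ether of compound 1 stays unchanged in compound 4, which shows that a change at this one position is enough to reach a measurable number. Compound 1 stands at a limit of the assay, and the step therefore has a floor but no exact size: the limit of > 200000 nM in this assay, at which 1 of the 4 values shown sits.

The carboxylic acid and the methoxy group enter together, and the compounds shown do not separate their shares in the step. On these data alone, whether the carboxylic acid alone, its methyl ester, an amide or an amine at this place would give a similar number remains open.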